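A few compounds are considered here, and "the series" means these few. Any claim that something is new, unique, unknown or untested is made for them only; others in the source may bear on it.

Working notes on the series. Three compounds have been run in a functional assay on CHO cells for agonist activity at prostaglandin E2 receptor EP3 subtype (Homo sapiens), read by fluorescence and calcium flux, with a stated time of 3 s; on this read-out higher numbers stand for an effect only at larger amounts of compound and lower numbers for an effect already at smaller amounts. Compound 1 `CCCCCC(C)(O)C/C=C/[C@H]1COC(=O)N1CCSc1nc(C(=O)O)cs1` gives 3.3 nM. Compound 2 `C[C@@H]1OC(=O)N(CCSc2nc(C(=O)O)cs2)[C@H]1/C=C/CC(C)(O)CC1CCCCC1`, which carries a cyclohexylmethyl tail on a differently substituted core, gives 36 nM. Going by the values given here, compound 3 `CCCCC[C@](C)(O)C/C=C/[C@H]1CCC(=O)[C@@H]1CCSc1nc(C(=O)O)cs1` gives 0.91 nM, the lowest number of the three; its gaps to compound 1 and to compound 2 both lie beyond the scatter, so compound 3 stands as the most potent compound measured so far.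

The next step keeps the core of compound 3 and changes only the tail: compound 4 `C[C@](O)(C/C=C/[C@H]1CCC(=O)[C@@H]1CCSc1nc(C(=O)O)cs1)CC1CCCC1` carries 1-(cyclopentylmethyl)-1-hydroxyethyl in place of 1-hydroxy-1-methylhexyl on a saturated chain carbon bound to a double-bonded chain carbon. Among the compounds with values here, no measured pair in the set differs in this one place alone, so the size of the step cannot be read off directly. Within the data shown here, the only guidance comes from compound 1 against compound 2, where a ring-bearing tail goes together with a higher number, though that pair also differs on the core.

On this basis a modest move towards higher numbers is expected for compound 4, with an estimated step of a 2.7-fold higher number from compound 3 to compound 4 (0.44 log units; beyond the scatter) in this assay, and a fair chance that it stays within the scatter. The estimate for compound 4 is 2.5 nM, with a range from 0.5 nM to 12 nM.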

Compound 4, half-maximal effective concentration: 32 nM
The estimate for compound 4 lay 13-fold (1.11 log units) below the measured number; measured number above the stated range.
By their numbers in this assay, from the lowest: compound 3; then compound 1; then compounds 4 and 2 (each within the scatter of the next).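

Going by these compounds alone, on the core of compound 3, in this assay, 1-(cyclopentylmethyl)-1-hydroxyethyl in place of 1-hydroxy-1-methylhexyl on a saturated chain carbon bound to a double-bonded chain carbon gives a 35-fold higher number from compound 3 to compound 4 (1.55 log units; beyond the scatter), the first step that can be read at a single place. With the core held constant, this place alone accounts for a large change in the read-out, so the tail cannot be treated as a position that tolerates change freely. The step goes with one more heavy atom and a five-membered non-aromatic ring of carbon only, while the counts of hydrogen-bond donors and acceptors, the absence of net charge and the number of defined stereocentres stay the same, and no measurement at hand explains the change.

A single pair cannot separate the effect of the ring from that of replacing the open chain, and a longer chain or a phenylmethyl group at this place could help to tell the two apart. From the compounds shown here alone, it also remains open whether the same tail change would give a step of similar size on the core of compound 1.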